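Replacing bromo with methoxy in compound 3

The source may report more compounds than this note shows. Statements on the series, on what has been measured and on what is new or still open speak of the compounds shown alone.

Measured in a functional assay on MCF7 cells (Homo sapiens) for inhibition, read by sulforhodamine B assay; on this read-out higher numbers stand for weaker inhibition and lower numbers for stronger inhibition:
- compound 1 `O=C1C=C(NC2CCCC2)C(=O)c2c1nc1n2[C@H]2OC[C@@H](O)[C@H]2OC1`: > 16000 nM (a limit)
- compound 2 `COc1ccccc1NC1=CC(=O)c2nc3n(c2C1=O)[C@H]1OC[C@@H](O)[C@H]1OC3`: > 4000 nM (a limit)
- compound 3 `O=C1C=C(Nc2ccc(Br)cc2)C(=O)c2c1nc1n2[C@H]2OC[C@@H](O)[C@H]2OC1`: 2580 nM

Of the three, compound 3 alone has a number, 2580 nM. Compound 1 reaches only a limit, > 16000 nM. Compound 2 also reaches only a limit, > 4000 nM.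

The next compound, compound 4 `COc1ccc(NC2=CC(=O)c3nc4n(c3C2=O)[C@H]2OC[C@@H](O)[C@H]2OC4)cc1`, differs from compound 3 by methoxy in place of bromo on an aromatic carbon, para to a large group.

Within the data shown here, two measured steps bear on this change. Placing 4-bromophenyl in place of cyclopentyl gave an at least 6.2-fold lower number from compound 1 to compound 3 (0.79 log units; beyond the scatter). Placing 4-bromophenyl in place of 2-methoxyphenyl gave an at least 1.5-fold lower number from compound 2 to compound 3 (0.19 log units; that floor lies within the scatter), a floor within the scatter and so only a weak guide. Among the measured compounds shown here, compound 2 is the only measured compound carrying a methoxy group, and it does so as 2-methoxyphenyl. A modest move toward weaker inhibition is therefore expected in this assay. The expected change is a 1.7-fold higher number from compound 3 to compound 4 (0.24 log units; within the scatter). For compound 4 the estimated value is 4500 nM, with an expected range from 1800 nM to 12000 nM.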

Compound 4, half-maximal inhibitory concentration: 5420 nM
The estimate for compound 4 lay 1.2-fold (0.08 log units) below the measured number; measured number inside the range.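

Within this assay, this is the first readable step at a place para to a large group on the aromatic ring, and methoxy in place of bromo there gave a higher number (a 2.1-fold higher number from compound 3 to compound 4 (0.32 log units; beyond the scatter)). The 4-methoxyphenyl group still gives a lower number than cyclopentyl (an at least 2.9-fold lower number from compound 1 to compound 4 (0.47 log units; beyond the scatter)), so the advantage over cyclopentyl seen with 4-bromophenyl does not depend on bromo alone. The step from compound 2 to compound 4 cannot be read, because compound 2 stands at a limit: the limit of > 4000 nM in this assay, at which 1 of the 4 values shown sits.

What the compounds shown leave open is how a plain phenyl group, with only hydrogen at this place, would compare with 4-bromophenyl and 4-methoxyphenyl. Also open, from the compounds shown here alone, is whether chloro, an amine or a carboxylic acid at this place would follow the same direction as methoxy.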